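Alkyl chain branching in a para-substituted aryl vinyl ketone series

The source may hold more compounds than are shown below. What is called first, only, known or untested is meant among the compounds shown, and "the series" means these compounds.

Compound 1: `C=CC(=O)c1ccc(CCC)cc1`
Compound 2: `C=CC(=O)c1ccc(CCCC)cc1`
Compound 3: `C=CC(=O)c1ccc(CCCCC)cc1`
Compound 4 (not yet measured): `C=CC(=O)c1ccc(CC(C)(C)C)cc1`

Affinity was read by an assay on isolated protein for displacement of a labelled ligand from thyroid hormone receptor alpha (Homo sapiens), read by fluorescence polarization; on this read-out higher numbers stand for weaker inhibition and lower numbers for stronger inhibition. In this assay compound 1 reaches only the assay limit, > 100000 nM; the value is a limit and not a number. Compound 2 gives 71000 nM. Compound 3 gives 60900 nM, the lowest of the two numbers recorded, with compound 2 nearest to it at a distance that lies within the scatter.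

The measured steps are small: an at least 1.4-fold lower number from compound 1 to compound 2 (0.14 log units; that floor lies within the scatter), an at least 1.6-fold lower number from compound 1 to compound 3 (0.21 log units; that floor lies within the scatter) and a 1.2-fold lower number from compound 2 to compound 3 (0.07 log units; within the scatter). Each extension of the chain moves the number only modestly, and the second of them is within the scatter.

Compound 4 differs from compound 3 as follows: tert-butyl in place of butyl on a saturated chain carbon bound to an aromatic carbon. For the measured compounds named here, no measured step tests branching of the chain; the existing steps vary only its length. With the same atoms rearranged and chain length producing little change, no step beyond the scatter is expected, though a move back toward the limit reached by compound 1 remains possible. Compound 4 is therefore estimated at 75000 nM, with a range of 30000 nM to 180000 nM, corresponding to an expected step of a 1.2-fold higher number from compound 3 to compound 4 (0.09 log units; within the scatter).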

Compound 4, half-maximal inhibitory concentration: 69600 nM
For compound 4 the middle estimate is 1.1-fold (0.03 log units) above the measured one, within the range that was stated.
By their numbers in this assay, from the lowest: compounds 3, 4 and 2 (each within the scatter of the next). At a limit, above all of these: compound 1.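

In this assay, joining the same atoms into a branched chain, pentyl to neopentyl, gives a 1.1-fold higher number from compound 3 to compound 4 (0.06 log units; within the scatter), so this first test of chain shape at this position leaves the read-out unresolved from the straight chain. Against the shorter straight chain, the change gives a 1.0-fold lower number from compound 2 to compound 4 (0.01 log units; within the scatter), again with no separation. The third comparison rests on an assay limit, not a number, and gives an at least 1.4-fold lower number from compound 1 to compound 4 (0.15 log units; that floor lies within the scatter), a floor only: the limit of > 100000 nM in this assay, at which 1 of the 4 values shown sits.

Whether any group at this position can move the number beyond the scatter remains open, since all the groups shown are plain saturated alkyl chains. A longer chain such as octyl, a cyclohexyl ring, or a chain ending in an amine or a carboxylic acid would address that question.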